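Swapping 3-methoxyphenyl for 4-iodophenyl in compound 3

A few compounds are considered here, and "the series" means these few. Any claim that something is new, unique, unknown or untested is made for them only; others in the source may bear on it.

Measured in a functional assay on MCF7 cells (Homo sapiens) for antiproliferative activity, read by MTT assay, with a stated time of 48 h; on this read-out higher numbers stand for weaker inhibition and lower numbers for stronger inhibition:
Compound 1 `Cc1ccc2nc(NC(c3cn(-c4ccccc4)nc3-c3cccc([N+](=O)[O-])c3)c3c(O)ccc4ccccc34)sc2c1`: 38400 nM
Compound 2 `Cc1ccc(-c2nn(-c3ccccc3)cc2C(Nc2nc3cc(C)c(C)cc3s2)c2c(O)ccc3ccccc23)cc1`: 22400 nM
Compound 3 `COc1cccc(-c2nn(-c3ccccc3)cc2C(Nc2nc3ccccc3s2)c2c(O)ccc3ccccc23)c1`: 16900 nM

Of the compounds shown here, three have been measured so far in this assay, and all three give values of a similar order. Compound 3 gives 16900 nM, which lies within the scatter of compound 2 at 22400 nM. Compound 1 gives 38400 nM, and the gap between it and compound 3 lies beyond the scatter, with compound 3 showing the stronger inhibition.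

The next compound to be tested is compound 4 `Oc1ccc2ccccc2c1C(Nc1nc2ccccc2s1)c1cn(-c2ccccc2)nc1-c1ccc(I)cc1`. It carries 4-iodophenyl in place of 3-methoxyphenyl on an aromatic carbon of a five-membered aromatic ring with 2 nitrogen (4-iodophenyl in place of 3-methoxyphenyl on an aromatic carbon).

Among the compounds with values here, no two measured compounds differ in one place only, so the effect of a single change like this one has not been observed directly. Within the data shown here, the only guide is the modest spread of the three values, and compound 3 at 16900 nM is the natural starting point. No step beyond the scatter is expected in this assay, and the estimated step is a 1.2-fold higher number from compound 3 to compound 4 (0.07 log units; within the scatter). Compound 4 is expected at 20000 nM, with an estimated range from 9000 nM to 45000 nM.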

Compound 4, half-maximal inhibitory concentration: 18900 nM
Estimate against measurement, compound 4: 1.1-fold (0.02 log units) above; the range from low to high includes it.
By their numbers in this assay, from the lowest: compounds 3, 4, 2 and 1 (each within the scatter of the next, the first and the last beyond it).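

Within the data shown here, this is the first pair in this assay that differs in one place only, and the step is a 1.1-fold higher number from compound 3 to compound 4 (0.05 log units; within the scatter), so compound 3 and compound 4 cannot be told apart on this read-out. At this aromatic carbon of the five-membered ring, the exchange replaces 3-methoxyphenyl, with its one hydrogen-bond acceptor, by 4-iodophenyl, which has none, and it also replaces oxygen-bearing methoxy by iodine at a different ring position, yet the two values stay within the scatter of each other. Nothing measured here explains why this pair reads alike.

From the compounds shown here alone, whether the position accepts other kinds of group remains open, for example an amine or a carboxylic acid on the phenyl ring, or a longer alkyl chain in place of that ring. Since compound 1 and compound 2 each differ from compound 3 in more than one place, the compounds shown also cannot separate the effect of the aryl group from that of the methyl groups elsewhere on the shared core.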